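Trimming a Propyl Chain on a Weak Receptor Binder

The source may hold more compounds than are shown below. What is called first, only, known or untested is meant among the compounds shown, and "the series" means these compounds.

Measured so far:
Compound 1, `CCc1cccc(CC)c1Nc1nc(C)nc(NCc2ccc(C(F)(F)F)cc2)n1`: in an assay on isolated protein for binding affinity to corticotropin-releasing factor receptor 1 (Homo sapiens) (a lower number here means a stronger inhibitor, a higher number a weaker inhibitor), compound 1 gives 55000 nM.
Compound 2, `CCCN(Cc1ccccc1)c1nc(C)nc(Nc2c(CC)cccc2CC)n1`: in this assay compound 2 gives > 10000 nM, which is a limit of the assay rather than a number.

Compound 2 therefore stands at the weak end of what this assay can resolve: it sits at the limit of > 10000 nM in this assay, at which 1 of the 2 values shown sits, so its inhibition constant is known only to lie beyond that limit. Among the compounds with values here, no step between the two measured compounds is counted here, since they differ in more than one place; all that can be said is that compound 1 gives a number, while compound 2 gives only a limit.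

Compound 3, `CCc1cccc(CC)c1Nc1nc(C)nc(N(CC)Cc2ccccc2)n1`, is the next compound to be measured. It differs from compound 2 by hydrogen in place of methyl on a saturated chain carbon, two bonds along the chain from a nitrogen on an aromatic ring. This is a small change. The step expected is a step that the limit leaves unreadable from compound 2 to compound 3, nothing beyond the usual scatter in either direction. Compound 3 is therefore expected to remain a weak binder, with an estimated inhibition constant of 20000 nM, within a range from 5000 nM to 80000 nM.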

Compound 3, inhibition constant: 1700 nM
Compound 3: the middle estimate sits 12-fold (1.07 log units) above what was measured; measured number outside the range, below it.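

Going from a propyl to an ethyl chain removes a single methyl, yet in this assay it gives an at least 5.8-fold lower number from compound 2 to compound 3 (0.76 log units; beyond the scatter). This position, on a saturated chain carbon two bonds along the chain from a nitrogen on an aromatic ring, therefore matters to receptor binding, and even the loss of one carbon can count here: compound 3 gives 1700 nM, a real number rather than a limit, which makes it a firm point of comparison for later changes at this chain. The true step may be larger than the printed one, and its full size cannot be read, because compound 2 is known only through a limit: the limit of > 10000 nM in this assay, at which 1 of the 3 values shown sits.

This is one step at one position, so it shows neither a trend with chain length nor the reason for the gain, and the evidence here gives no property of either chain that would explain it. As far as these compounds go, whether a methyl in place of the ethyl, a longer chain such as butyl, or a chain ending in an amine would bind more or less tightly than compound 3 remains open.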